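This account rests on a few compounds, and the source may have more. Where it says the series, first, only, none or still open, it means among the compounds named here.

Working notes on the series.

Compound 1 `COc1ccc(OC)c(/C=N/c2c(C#N)ncn2-c2ccc(F)cc2)c1` is measured in a functional assay on A549 cells (Homo sapiens) for antiproliferative activity, read by MTT assay, with a stated time of 48 h (on this read-out higher numbers stand for weaker inhibition and lower numbers for stronger inhibition), and gives 9280 nM. Compound 2 `COc1cc(/C=N/c2c(C#N)ncn2-c2ccc(F)cc2)ccc1O` gives 13600 nM in this assay. The difference between the cores of compound 1 and compound 2 is not broken down here; their two values lie within the usual scatter of each other, so no order between them is drawn.

Compound 3 `COc1ccc(OC)c(/C=N/c2c(C#N)ncn2Cc2ccc(F)cc2)c1` carries the change 4-fluorobenzyl in place of 4-fluorophenyl on an aromatic nitrogen relative to compound 1. In this assay compound 3 gives 13100 nM; the resulting step is a 1.4-fold higher number from compound 1 to compound 3 (0.15 log units; within the scatter), within the scatter.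

Compound 4 `COc1cc(/C=N/c2c(C#N)ncn2Cc2ccc(F)cc2)ccc1O` is not yet measured. It differs from compound 2 by 4-fluorobenzyl in place of 4-fluorophenyl on an aromatic nitrogen, the same change as that from compound 1 to compound 3, made at the same place on the same kind of ring. Because the earlier step was a 1.4-fold higher number from compound 1 to compound 3 (0.15 log units; within the scatter), an equally small step is expected from compound 2 to compound 4, estimated at a 1.3-fold higher number from compound 2 to compound 4 (0.12 log units; within the scatter). Among the compounds with values here, compound 4 is therefore expected to give about 18000 nM in this assay, with a likely range from 9000 nM to 40000 nM, resting only on the single earlier instance of this change.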

Compound 4, half-maximal inhibitory concentration: 10900 nM
Compound 4: the middle estimate sits 1.7-fold (0.22 log units) above what was measured; the measured number falls inside the stated range.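

In this assay, the second instance of 4-fluorobenzyl in place of 4-fluorophenyl on an aromatic nitrogen gives a 1.2-fold lower number from compound 2 to compound 4 (0.10 log units; within the scatter). Set beside the first instance, the two steps do not differ by more than repeated measurement would allow: the same change on two cores in this assay, a 1.4-fold higher number (0.15 log units; within the scatter) from compound 1 to compound 3 and a 1.2-fold lower number (0.10 log units; within the scatter) from compound 2 to compound 4, 1.8-fold (0.25 log units) apart, within the scatter of two such steps. On these two cores the change therefore leaves the number within the scatter each time, and no dependence on the core can be read; this does not show that the change is without effect on other cores, and neither step gives it a direction or a size.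

The compounds shown leave open whether any other group on this aromatic nitrogen would move the number beyond the scatter, for example a longer chain such as 2-phenylethyl or a chain ending in an amine. They also leave open what would follow if the cyano group were replaced by a carboxylic acid or an amide.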